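Moving a Chlorine Around the Phenyl Ring

The compounds below may be only part of what the source reports. "The series", "measured", "known", "first", "only" and "open" are said of these compounds alone.

Of the compounds shown here, three sharing one core have been tested in a toxicity assay on THP-1 cells (Homo sapiens) for inhibition; on this read-out higher numbers stand for lower toxicity in this test and lower numbers for higher toxicity in this test. Compound 1 `Cn1c(-c2ccccc2F)cnc1NC(=O)c1ccc(F)cc1` carries a 2-fluorophenyl on an aromatic carbon of the shared core. In this assay compound 1 reaches only the limit > 100000 nM, so no number is known for it. Compound 2 `Cn1c(-c2cccc(Br)c2)cnc1NC(=O)c1ccc(F)cc1` carries a 3-bromophenyl instead. For compound 2 this assay also gives only a limit, > 50000 nM. For the measured compounds named here, compound 3 `Cn1c(-c2ccc(Cl)cc2)cnc1NC(=O)c1ccc(F)cc1`, with a 4-chlorophenyl, is the only one with a measured number: in this assay compound 3 gives 37000 nM, the lowest reading of the three. The step of an at least 2.7-fold lower number from compound 1 to compound 3 (0.43 log units; beyond the scatter) is the one clear movement, the step of an at least 1.3-fold lower number from compound 2 to compound 3 (0.13 log units; that floor lies within the scatter) stays within the scatter, and the step that the two limits leave unreadable from compound 1 to compound 2 cannot be read because both ends are limits.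

Compound 4 `Cn1c(-c2ccccc2Cl)cnc1NC(=O)c1ccc(F)cc1` differs from compound 3 by 2-chlorophenyl in place of 4-chlorophenyl on an aromatic carbon. This change returns the halogen to the same position it holds in compound 1, whose reading sits at a limit because of the limit of > 100000 nM in this assay, at which 1 of the 3 values shown sits. Going by the values given here, the step of an at least 2.7-fold lower number from compound 1 to compound 3 (0.43 log units; beyond the scatter) is the only measured step bearing on this change, and it ran the other way. The number for compound 4 is therefore expected to rise again, with an expected step of a 2.2-fold higher number from compound 3 to compound 4 (0.33 log units; beyond the scatter). Compound 4 is estimated at 80000 nM, somewhere between 30000 nM and 200000 nM.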

Compound 4, half-maximal cytotoxic concentration: > 50000 nM
Compound 4 gave a limit, no number; the forecaster's own chance of this, stated with the estimate: 50%; the middle value lies beyond the limit too.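

Exchanging the 4-chlorophenyl for a 2-chlorophenyl keeps the same atoms and moves only the chlorine, and in this assay this gives an at least 1.3-fold higher number from compound 3 to compound 4 (0.13 log units; that floor lies within the scatter), so a real rise is possible but not shown. For the compounds shown here, compound 4 gives no number, only a limit, and it is the second compound in the set to stop at this value: the limit of > 50000 nM in this assay, at which 2 of the 4 values shown sit. The steps that link compound 4 to compound 1 and to compound 2 cannot be read, as both ends of each are limits, which leaves compound 3 as the only compound of the four with a measured number.

From the compounds shown here alone, it stays open how a 3-chlorophenyl would read in this assay, a group that would put the same chlorine at the one place on the phenyl ring still missing from this small series. Also open, going by these compounds, is whether a phenyl ring carrying an amine or a carboxylic acid instead of a halogen would give a measured number at all, rather than another limit.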